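Aryl exchange from compound 2 to compound 3

The compounds below may be only part of what the source reports. "The series", "measured", "known", "first", "only" and "open" are said of these compounds alone.

In an in vitro ADME assay on microsomes from liver (Rattus norvegicus) for metabolic stability (on this read-out lower numbers stand for slow clearance and higher numbers for fast clearance), compound 1 `CC(C)NC(=O)[C@H]1CC[C@@H](n2/c(=N/C(=O)c3cccc(C#N)c3)[nH]c3ccc(CN4CCC(C(C)(C)O)CC4)cc32)CC1` gives 17 mL.min-1.g-1 and compound 2 `CC(C)NC(=O)[C@H]1CC[C@@H](n2/c(=N/C(=O)c3cc(F)cc(C#N)c3)[nH]c3ccc(CN4CCC(C(C)(C)O)CC4)cc32)CC1` gives 30 mL.min-1.g-1. Within the data shown here, compound 2 therefore stands within the scatter of compound 1, its only measured neighbour. Among the measured compounds shown here, the single measured step, a 1.8-fold higher number from compound 1 to compound 2 (0.25 log units; within the scatter), is a fluoro in place of hydrogen on an aromatic carbon and stays within the scatter. Compound 3 `CC(C)NC(=O)[C@H]1CC[C@@H](n2/c(=N/C(=O)c3ccc(F)c(Cl)c3)[nH]c3ccc(CN4CCC(C(C)(C)O)CC4)cc32)CC1` differs from compound 2 as follows: 3-chloro-4-fluorophenyl in place of 3-cyano-5-fluorophenyl on a carbonyl carbon. In words, this is 3-chloro-4-fluorophenyl in place of 3-cyano-5-fluorophenyl on a carbonyl carbon. For the measured compounds named here, no measured compound carries the entering group, and no measured step removes the nitrile, so the series offers only weak guidance. The expected change is small and is not estimated to exceed the scatter: a 1.2-fold higher number from compound 2 to compound 3 (0.07 log units; within the scatter). For compound 3 the estimated value in this assay is 35 mL.min-1.g-1, with an expected range of 15 mL.min-1.g-1 to 75 mL.min-1.g-1.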

Compound 3, intrinsic clearance in microsomes: 44 mL.min-1.g-1
Estimate against measurement, compound 3: 1.3-fold (0.10 log units) below; measured number inside the range.
By their numbers in this assay, from the lowest: compounds 1, 2 and 3 (each within the scatter of the next, the first and the last beyond it).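

In this assay the exchange on the carbonyl carbon gives a step that stays small (a 1.5-fold higher number from compound 2 to compound 3 (0.17 log units; within the scatter)), so 3-chloro-4-fluorophenyl and 3-cyano-5-fluorophenyl cannot be told apart here, even though the nitrile is gone. Among these compounds, measured against 3-cyanophenyl, the same position gives the first step beyond the scatter (a 2.6-fold higher number from compound 1 to compound 3 (0.41 log units; beyond the scatter)), a modest one, showing that the aryl group on this carbonyl carbon can shift the read-out measurably. Nothing available explains either step.

The compounds shown do not separate the parts of the step from compound 1, which could lie with the loss of the nitrile, the entry of the chlorine or the entry of the fluorine. On these data alone, how a pyridine ring or a methoxy-bearing phenyl on this carbonyl carbon would read also remains open.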